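The source may hold more compounds than are shown below. What is called first, only, known or untested is meant among the compounds shown, and "the series" means these compounds.

Of the compounds shown here, three sharing one core have been tested in a functional assay on NCI-H1975 cells (Homo sapiens) for inhibition, read by MTT assay, with a stated time of 72 h; a higher number here means a weaker inhibitor, a lower number a stronger inhibitor. Compound 1 `C=CC(=O)Nc1cccc(NC(=O)CSc2nc(Nc3cccc(Cl)c3)c3ccccc3n2)c1` gives 9460 nM, compound 2 `C=CC(=O)Nc1cccc(NC(=O)CSc2nc(Nc3ccc(Cl)cc3)c3ccccc3n2)c1` gives 7580 nM, and compound 3 `C=CC(=O)Nc1cccc(NC(=O)CSc2nc(Nc3ccc(Cl)c(Cl)c3)c3ccccc3n2)c1` gives 19100 nM, the highest of the three numbers. Compound 4 `C=CC(=O)Nc1cccc(NC(=O)CSc2nc(Nc3ccc(Cl)cc3Cl)c3ccccc3n2)c1` differs from compound 3 by 2,4-dichlorophenyl in place of 3,4-dichlorophenyl on a nitrogen on an aromatic ring. Going by the values given here, the nearest precedent is a change in where one chloro sits, a 1.2-fold lower number from compound 1 to compound 2 (0.10 log units; within the scatter), which altered little. Adding a chloro, as in a 2.0-fold higher number from compound 1 to compound 3 (0.31 log units; beyond the scatter) and a 2.5-fold higher number from compound 2 to compound 3 (0.40 log units; beyond the scatter), raised the number modestly, but here nothing is added, only rearranged. For compound 4 the expected step is therefore a 1.1-fold lower number from compound 3 to compound 4 (0.05 log units; within the scatter), leaving the number near that of compound 3. The estimate for compound 4 is 17000 nM, with a range from 6500 nM to 45000 nM.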

Compound 4, half-maximal inhibitory concentration: 5990 nM
The estimate for compound 4 lay 2.8-fold (0.45 log units) above the measured number, and the stated range ends above it.
By their numbers in this assay, from the lowest: compounds 4, 2 and 1 (each within the scatter of the next); then compound 3.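

Rearranging the two chloro groups, with the same atoms overall, gives a 3.2-fold lower number from compound 3 to compound 4 (0.50 log units; beyond the scatter), so on this ring the place of a chloro can matter and not only the number of chloro groups. Compound 4 falls within the scatter of both single-chloro compounds, with a 1.3-fold lower number from compound 2 to compound 4 (0.10 log units; within the scatter) and a 1.6-fold lower number from compound 1 to compound 4 (0.20 log units; within the scatter). A second chloro therefore raised the number in one case and not in the other, though that gap is not firm: the same change on two cores in this assay, a 2.0-fold higher number (0.31 log units; beyond the scatter) from compound 1 to compound 3 and a 1.3-fold lower number (0.10 log units; within the scatter) from compound 2 to compound 4, 2.6-fold (0.41 log units) apart, within the scatter of two such steps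

The compounds shown carry only chloro or hydrogen on this ring. As far as these compounds go, how a fluoro or a methoxy in place of chloro would behave remains open.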